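Phenoxy added at the benzamide end of the core

The compounds below may be only part of what the source reports. "The series", "measured", "known", "first", "only" and "open" are said of these compounds alone.

Measured compounds:
- compound 1 `CC(/C=N/Nc1ccc([N+](=O)[O-])cc1)=N\NC(=O)c1ccccc1`: > 12000 nM
- compound 2 `CC(/C=N/Nc1ccc([N+](=O)[O-])cc1)=N\NC(=O)c1ccc(C(F)(F)F)cc1`: > 12000 nM
- compound 3 `CC(/C=N/Nc1ccc([N+](=O)[O-])cc1)=N\NC(=O)c1cccc(C)c1`: > 12000 nM

In a functional assay on cells (Splenocyte, Mus musculus, strain BALB/c) for inhibition, read by scintillation counting and thymidine incorporation, with a stated time of 72 h (a higher number here means a weaker inhibitor, a lower number a stronger inhibitor), compound 1 gives > 12000 nM, which is a limit of the assay and not a number. For compound 2 the value > 12000 nM is likewise a limit. For compound 3 the value > 12000 nM is also a limit. All three values sit at the same limit (the limit of > 12000 nM in this assay, at which 3 of the 3 values shown sit), so where compound 1 stands among them cannot be told.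

Compound 4 `CC(/C=N/Nc1ccc([N+](=O)[O-])cc1)=N\NC(=O)c1ccccc1Oc1ccccc1` differs from compound 1 by phenoxy in place of hydrogen on an aromatic carbon. Among the measured compounds shown here, the steps that bear on a substituent entering the same ring are a step that the two limits leave unreadable from compound 1 to compound 2 and a step that the two limits leave unreadable from compound 1 to compound 3; both are unreadable in size because both ends sit at the limit (the limit of > 12000 nM in this assay, at which 3 of the 3 values shown sit). For the measured compounds named here, they give no direction for the step into compound 4 in this assay, and a value at the limit again is the most likely outcome.

The step from compound 1 to compound 4 is therefore expected to be a step that the limit leaves unreadable from compound 1 to compound 4. For compound 4 in this assay the estimated value is 15000 nM, within 4000 nM to 60000 nM.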

Compound 4, half-maximal inhibitory concentration: > 12000 nM
Compound 4 ended at the assay's limit; the forecaster's own chance of this, stated with the estimate: 80%; the middle value is on the limit's open side.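

No step from compound 1 to compound 4 can be read, because both values are limits of the assay, as are those of compound 2 and compound 3: the limit of > 12000 nM in this assay, at which 4 of the 4 values shown sit.

The compounds shown leave open how these four compare in this assay and which change to the shared core would give a readable value.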